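Expected clearance after the pyridin-4-yl swap

The compounds below may be only part of what the source reports. "The series", "measured", "known", "first", "only" and "open" are said of these compounds alone.

- Compound 1 `O=c1[nH]c2ccc(-c3nnc(NCc4ccccc4)o3)cc2o1`: 69 mL.min-1.g-1
- Compound 2 `Fc1cccc(CNc2nnc(-c3c[nH]c4ncccc34)o2)c1`: 54 mL.min-1.g-1

In an ADME assay (liver) for metabolic stability, with Liver microsome (Homo sapiens) as the target, using microsomes (on this read-out lower numbers stand for slow clearance and higher numbers for fast clearance), compound 2 at 54 mL.min-1.g-1 stands within the usual scatter of compound 1 at 69 mL.min-1.g-1. Compound 3 `c1cnc2[nH]cc(-c3nnc(NCc4ccncc4)o3)c2c1` differs from compound 2 by pyridin-4-yl in place of 3-fluorophenyl on a saturated chain carbon bound to a nitrogen on an aromatic ring: pyridin-4-yl in place of 3-fluorophenyl. Within the data shown here, no measured pair shows this change, and the expectation starts from compound 2 at 54 mL.min-1.g-1. The expected change in this assay is a modest fall just beyond the scatter, a 2.2-fold lower number from compound 2 to compound 3 (0.33 log units; beyond the scatter). For compound 3 the estimated value is 25 mL.min-1.g-1, with an expected range of 10 mL.min-1.g-1 to 55 mL.min-1.g-1.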

Compound 3, intrinsic clearance in microsomes: < 14 mL.min-1.g-1
Compound 3 ended at the assay's limit; the forecaster's own chance of this, stated with the estimate: 10%; middle value at least 1.7-fold (0.25 log units) from the limit.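

On the saturated chain carbon bound to a nitrogen on an aromatic ring, pyridin-4-yl in place of 3-fluorophenyl gives an at least 3.8-fold lower number from compound 2 to compound 3 (0.58 log units; beyond the scatter), the only step shown and one that lies beyond the scatter in this assay. Compound 1 and compound 2 differ in more than one place, so they could not show that clearance responds to this change. Compound 3 gives a limit and not a number, so the step's full size stays unknown: the limit of < 14 mL.min-1.g-1 in this assay, at which 1 of the 3 values shown sits.

The compounds shown leave open whether the step follows the ring nitrogen or the loss of the fluorine, which a plain phenyl on the same carbon would separate. On these data alone, how a piperidine there would read in this assay also stays open.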